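The compounds below may be only part of what the source reports. "The series", "measured", "known", "first", "only" and "open" are said of these compounds alone.

Among the compounds with values here, in an ADME assay on MDCK cells (Canis lupus familiaris) for cytotoxicity, with a stated time of 48 h (on this read-out higher numbers stand for lower toxicity in this test and lower numbers for higher toxicity in this test), compound 1 `C=C(C(=O)OC)[C@@H]1CC[C@H](C)[C@H]2C(=C(C)C(=O)[C@H]2NC(=O)c2ccccc2)C1` gives 84.3 uM, the second highest of the three numbers so far. Compound 2 `C=C(C(=O)OC)[C@@H]1CC[C@H](C)[C@H]2C(=C(C)C(=O)[C@H]2NC(=O)CNC(=O)c2ccccc2)C1` gives 488 uM, and compound 3 `C=C(C(=O)OC)[C@@H]1CC[C@H](C)[C@H]2C(=C(C)C(=O)[C@H]2NS(=O)(=O)c2ccc(F)cc2)C1` gives 25.1 uM.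

The step under review leads to compound 4 `C=C(C(=O)OC)[C@@H]1CC[C@H](C)[C@H]2C(=C(C)C(=O)[C@H]2NC(=O)c2ccc(B(O)O)cc2)C1`, which keeps the shared core and the benzoyl amide of compound 1. The change is a group of 3 heavy atoms (1 boron, 2 oxygen; no ring) in place of a hydrogen atom, on an aromatic carbon, on an aromatic carbon of a six-membered aromatic ring of carbon only, para to a large group.

Within the data shown here, two measured steps bear on this only indirectly, since both replace a larger part of the side chain: a 5.8-fold higher number from compound 1 to compound 2 (0.76 log units; beyond the scatter) and a 3.4-fold lower number from compound 1 to compound 3 (0.53 log units; beyond the scatter). Both are modest, beyond the scatter and opposite in direction. Among the measured compounds shown here, no measured pair isolates a new group on this ring, so the data give no direction, and a step no larger than these modest ones is expected in this assay, most likely a small one.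

The expected step is a 1.2-fold lower number from compound 1 to compound 4 (0.08 log units; within the scatter). For compound 4 the estimate is 70 uM, with an expected range of 22 uM to 220 uM.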

Compound 4, half-maximal toxic concentration: 188 uM
Compound 4: middle estimate off by 2.7-fold (0.43 log units), on the low side; low and high end bracket the measured number.
By their numbers in this assay, from the lowest: compound 3; then compound 1; then compound 4; then compound 2.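

In this assay, a first substituent on this ring, a group of 3 heavy atoms (1 boron, 2 oxygen; no ring) para to a large group, moves the number upward, not downward (a 2.2-fold higher number from compound 1 to compound 4 (0.35 log units; beyond the scatter)). This position therefore accepts added heavy atoms without a higher toxicity in this test, although the change to the ring alone does not reach compound 2 (a 2.6-fold lower number from compound 2 to compound 4 (0.41 log units; beyond the scatter)). Nothing available explains the rise, so the step stands as an observation only.

Open, from the compounds shown here alone, is whether another group at this place, such as a carboxylic acid or an amine, would shift the number in the same direction. Also open, going by these compounds, is whether the boron-bearing group would raise the number on the ring of compound 2 as it does on that of compound 1.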